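The source may report more compounds than this note shows. Statements on the series, on what has been measured and on what is new or still open speak of the compounds shown alone.

Measured so far:
compound 1, `N=C(N)NCCC[C@H](NC(=O)CN(c1nc(Cl)nc2[nH]cnc12)C1CC1)C(=O)O`: 7.19%
compound 2, `N=C(N)NCCC[C@H](NC(=O)CN(c1nc(Cl)nc2[nH]cnc12)C1CC1)C(=O)OCc1ccccc1`: 6.12%

In a functional assay on the whole organism (Tail, strain ICR) with Mus musculus as the target, in the tail flick test, with a stated time of 150 min, at a dose of 25 umol/kg by the oral route (a higher number here means a stronger effect of the compound at the dose given, a lower number a weaker effect), compound 1 gives the higher of the two numbers, and the step of a number 1.1 percentage points lower from compound 1 to compound 2 (within the scatter) shows that compound 2 is not distinguishable from it. Compound 3, `O=C(O)CC[C@H](NC(=O)CN(c1nc(Cl)nc2[nH]cnc12)C1CC1)C(=O)O`, has not been measured. It differs from compound 1 by a group of 3 heavy atoms (1 carbon, 2 oxygen; no ring) in place of a group of 5 heavy atoms (2 carbon, 3 nitrogen; no ring), on a saturated chain carbon, three bonds along the chain from an amide-type nitrogen and a carbonyl carbon. Going by the values given here, no measured step touches this part of the molecule; the only step on record concerns the ester end and lies within the scatter. With both measured values low, compound 3 is expected to stay low as well, so the step of a number 1.2 percentage points lower from compound 1 to compound 3 (within the scatter) is an expectation of no change beyond the scatter. Compound 3 is therefore estimated at 6%, between 0% and 16%.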

Compound 3, a percentage reported as activity, at one dose (the size of the read-out at that dose, not a potency): 29.5%
Estimate against measurement, compound 3: 23.5 percentage points below; the whole stated range lies below it.
By their numbers in this assay, from the lowest: compounds 2 and 1 (each within the scatter of the next); then compound 3.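

In this assay, going by these compounds alone, this position, on a saturated chain carbon, is the first place where a change moves the read-out beyond the scatter: carboxy in place of the group of 5 heavy atoms gives a number 22.3 percentage points higher from compound 1 to compound 3 (beyond the scatter) at this dose. The earlier step at the ester end did not leave the scatter, so the chain end counts here and the ester end did not. No evidence on hand bears on the reason for this step. On these data alone, whether an amine or a longer chain ending in a carboxylic acid at this place would give a similar read-out stays open, as does the effect of a benzyl ester on compound 3.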